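The compounds below may be only part of what the source reports. "The series", "measured", "known", "first", "only" and "open" are said of these compounds alone.

Measured so far:
compound 1, `O=C([C@@H]1CCCN(S(=O)(=O)c2ccc(S(=O)(=O)C3CCC3)cc2)C1)N1CCC(F)(F)CC1`, gives 9 nM in a functional assay on MIA PaCa-2 cells (Homo sapiens) for inhibition, read by MTT assay, with a stated time of 7 days; a higher number here means a weaker inhibitor, a lower number a stronger inhibitor.
compound 2, `CC(C)S(=O)(=O)c1ccc(S(=O)(=O)N2CCC[C@@H](C(=O)N3CCC(F)(F)CC3)C2)cc1`, gives 11 nM in this assay.
compound 3, `CCN(CC)S(=O)(=O)c1ccc(S(=O)(=O)N2CCC[C@@H](C(=O)N3CC[C@@H](OC)C3)C2)cc1`, gives 3910 nM in this assay.

Of these three, compound 3 gives the highest number and is the weakest inhibitor; both compound 1 and compound 2 lie far lower, well beyond the usual scatter. Compound 4, `CCN(CC)S(=O)(=O)c1ccc(S(=O)(=O)N2CCC[C@@H](C(=O)NC3CCOCC3)C2)cc1`, has not yet been measured in this assay. It keeps the diethylamino sulfonyl portion of compound 3 and changes only the amide end: (oxan-4-yl)amino in place of 3-methoxypyrrolidin-1-yl on a carbonyl carbon.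

Among the compounds with values here, the one measured step, a 1.2-fold higher number from compound 1 to compound 2 (0.09 log units; within the scatter), touches the sulfonyl sulfur, not the carbonyl carbon, and stays within the scatter; it says nothing about this change. Compound 1 and compound 2 carry a different amide group from compound 3, but they also differ at the sulfonyl end, so their low numbers cannot be tied to the amide alone. Within the data shown here, with no step bearing on the change, the expected step of a 1.3-fold lower number from compound 3 to compound 4 (0.12 log units; within the scatter) is none beyond the scatter in either direction, though the uncertainty is wide. Compound 4 is therefore estimated to give 3000 nM in this assay, with a range from 600 nM to 15000 nM.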

Compound 4, half-maximal inhibitory concentration: 3770 nM
Compound 4: middle estimate off by 1.3-fold (0.10 log units), on the low side; the range from low to high includes it.
By their numbers in this assay, from the lowest: compounds 1 and 2 (each within the scatter of the next); then compounds 4 and 3 (each within the scatter of the next).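

Within the data shown here, with the diethylamino sulfonyl end held fixed, placing (oxan-4-yl)amino on the carbonyl carbon instead of 3-methoxypyrrolidin-1-yl gives a 1.0-fold lower number from compound 3 to compound 4 (0.02 log units; within the scatter) in this assay, which is the first direct reading of a change at this position. The two groups have the same heavy atoms, yet the exchange turns a five-membered ring into a six-membered one, adds a hydrogen-bond donor and removes a defined stereocentre, and together these differences leave the two compounds within the scatter of each other. No measurement shown here explains this result.

Compounds 1 and 2 differ from compound 3 and compound 4 at both the sulfonyl end and the amide end, which leaves open whether their much lower numbers come from the amide group, the sulfonyl group or the two together. Also open, as far as these compounds go, is how this position would respond to a different kind of group on the carbonyl carbon, such as dimethylamino or a short chain ending in a carboxylic acid.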